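Removing a Fluoro Group From an Algal Growth Inhibitor

The compounds below may be only part of what the source reports. "The series", "measured", "known", "first", "only" and "open" are said of these compounds alone.

Three measured compounds share one core. Compound 2 `CC(C)OC(=O)c1cc(N2C(=O)C3=C(CCCC3)C2=O)c(F)cc1Cl` gives 89.1 nM in a functional assay on the whole organism with Scenedesmus acutus as the target, with a stated time of 20 h; on this read-out lower numbers stand for stronger inhibition and higher numbers for weaker inhibition. Compound 1 `CC(C)OC(=O)c1cc(N2C(=O)C3=C(CCCC3)C2=O)ccc1Cl` differs from it by hydrogen in place of fluoro on an aromatic carbon, a change that gave a 2.0-fold higher number from compound 2 to compound 1 (0.31 log units; beyond the scatter). Compound 3 `CC(C)COC(=O)c1cc(N2C(=O)C3=C(CCCC3)C2=O)c(F)cc1Cl` differs from compound 2 by isobutyl in place of isopropyl on an oxygen next to a carbonyl group, and in this assay compound 3 gives 407 nM, while compound 1 gives 182 nM. That step was a 4.6-fold higher number from compound 2 to compound 3 (0.66 log units; beyond the scatter).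

Compound 4 `CC(C)COC(=O)c1cc(N2C(=O)C3=C(CCCC3)C2=O)ccc1Cl` has not been measured. It differs from compound 3 by hydrogen in place of fluoro on an aromatic carbon. This is the same kind of change as from compound 2 to compound 1, though the surroundings differ: here the place is para to an isobutoxycarbonyl group rather than para to an isopropoxycarbonyl group. Because the earlier step was a 2.0-fold higher number from compound 2 to compound 1 (0.31 log units; beyond the scatter), a similar step is expected, a 2.0-fold higher number from compound 3 to compound 4 (0.29 log units; within the scatter). Compound 4 is therefore estimated at 800 nM in this assay, expected to fall between 350 nM and 1800 nM.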

Compound 4, half-maximal inhibitory concentration: 15500 nM
For compound 4 the middle estimate is 19-fold (1.29 log units) below the measured one; the measured number lies above the stated range.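

Putting hydrogen in place of fluoro gave a 38-fold higher number from compound 3 to compound 4 (1.58 log units; beyond the scatter) in this assay, so this change did not carry over at the size seen with the isopropoxycarbonyl group: the same change on two cores in this assay, a 2.0-fold higher number (0.31 log units; beyond the scatter) from compound 2 to compound 1 and a 38-fold higher number (1.58 log units; beyond the scatter) from compound 3 to compound 4, 19-fold (1.27 log units) apart, beyond the scatter of two such steps. Seen from the other side, isobutyl in place of isopropyl gave an 85-fold higher number from compound 1 to compound 4 (1.93 log units; beyond the scatter) without the fluoro group, which also differs from the step with fluoro present: the same change on two cores in this assay, a 4.6-fold higher number (0.66 log units; beyond the scatter) from compound 2 to compound 3 and an 85-fold higher number (1.93 log units; beyond the scatter) from compound 1 to compound 4, 19-fold (1.27 log units) apart, beyond the scatter of two such steps. In these four compounds, the effect of each change depends on the other, but this single set shows neither why that is nor whether it holds for other groups on the ester oxygen.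

As far as these compounds go, it remains open how an ethyl or a longer n-butyl chain on that oxygen would behave with and without fluoro. From the compounds shown here alone, whether a chloro group in place of that fluoro would behave like fluoro also remains open.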